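The source may report more compounds than this note shows. Statements on the series, on what has been measured and on what is new or still open speak of the compounds shown alone.

In a functional assay on ZR-75-1 cells (Homo sapiens) for inhibition, read by MTT assay, with a stated time of 24 h (a higher number here means a weaker inhibitor of growth, a lower number a stronger inhibitor of growth), three compounds that share one core have been measured. Compound 1 (`N[C@@H](CC(=O)OC[C@H]1O[C@@H](n2cc(F)c(=O)[nH]c2=O)C[C@@H]1O)C(=O)O`) gives 3900000 nM, compound 2 (`N[C@@H](CC(=O)OC[C@H]1O[C@@H](n2cc(F)c(=O)[nH]c2=O)C[C@@H]1OC(=O)C[C@H](N)C(=O)O)C(=O)O`) gives 1900000 nM, and compound 3 (`CC(C)[C@H](N)C(=O)OC[C@H]1O[C@@H](n2cc(F)c(=O)[nH]c2=O)C[C@@H]1O`) gives 2500000 nM. Compound 3 lies within the scatter of both compound 1 and compound 2, so it cannot be ranked against either, although those two stand apart. Putting 1-amino-2-methylpropyl in place of 2-amino-2-carboxyethyl on a carbonyl carbon gives a 1.6-fold lower number from compound 1 to compound 3 (0.19 log units; within the scatter), which does not separate the two compounds.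

Compound 4 (`CC(C)[C@H](N)C(=O)OC[C@H]1O[C@@H](n2cc(F)c(=O)[nH]c2=O)C[C@@H]1OC(=O)[C@@H](N)C(C)C`) is compound 3 with (1-amino-2-methylpropyl)carbonyl in place of hydrogen on an oxygen on a saturated carbon. Going by the values given here, the nearest precedent is the matching change with (2-amino-2-carboxyethyl)carbonyl, which gives a 2.1-fold lower number from compound 1 to compound 2 (0.31 log units; beyond the scatter), a modest step only just beyond the scatter. That is a single pair with a different entering group, so the guide is thin. A similar modest step toward a lower number is therefore expected in this assay, and it may not clear the scatter. The expected change is a 1.9-fold lower number from compound 3 to compound 4 (0.28 log units; within the scatter). For compound 4 the estimate is 1300000 nM, with an expected range of 600000 nM to 2800000 nM.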

Compound 4, concentration for 50% growth inhibition: 2800000 nM
Estimate against measurement, compound 4: 2.2-fold (0.33 log units) below, within the range that was stated.
By their numbers in this assay, from the lowest: compounds 2, 3, 4 and 1 (each within the scatter of the next, the first and the last beyond it).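

In this assay, replacing the hydroxy at this position with ((1-amino-2-methylpropyl)carbonyl)oxy gives a 1.1-fold higher number from compound 3 to compound 4 (0.05 log units; within the scatter) and so does not separate the two compounds. Going by these compounds alone, the only earlier reading of a change on this oxygen was a 2.1-fold lower number from compound 1 to compound 2 (0.31 log units; beyond the scatter) with (2-amino-2-carboxyethyl)carbonyl as the entering group, and the new pair shows that placing an amino acid-derived acyl group on this oxygen does not in itself give a step beyond the scatter. No measurement available here bears on the reason for this result.

The compounds shown leave open whether the outcome at this oxygen depends on the entering group or on the group already carried at the other ester, since the two pairs differ in both. A (2-amino-2-carboxyethyl)carbonyl group placed on this oxygen of compound 3, or a simple acetyl group with neither an amine nor a carboxylic acid, would help to separate those two possibilities.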